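This account rests on a few compounds, and the source may have more. Where it says the series, first, only, none or still open, it means among the compounds named here.

Three compounds have so far been tested in an ADME assay on Huh-7 cells (Homo sapiens) for cytotoxicity; a lower number here means that less compound is tolerated, a higher number that more compound is tolerated:

Compound 1 `NC(=S)N1CCCc2c(OCCCCCOc3cccc4ccccc34)cccc21`: > 50000 nM, a limit of the assay rather than a number.
Compound 2 `O=C(NC(=S)N1CCc2c(OCCCCCOc3ccc(Cl)cc3)cccc21)Oc1ccccc1`: > 50000 nM, a limit of the assay.
Compound 3 `CN(C)c1ccc(C(=O)NC(=S)N2CCc3c(OCCCCCOc4ccc(Cl)cc4)cccc32)cc1`: > 50000 nM, a limit of the assay.

Compound 3 therefore stands exactly where the other two stand: at the upper edge of what this assay can read, with no number of its own. For the measured compounds named here, the one measured step that reaches compound 3, a step that the two limits leave unreadable from compound 2 to compound 3, cannot be sized, since both of its ends are limits. Going by the values given here, the only evidence available is the limit of > 50000 nM in this assay, at which 3 of the 3 values shown sit, which shows no compound yet reaching a readable value.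

Compound 4 `O=C(NC(=S)N1CCc2c(OCCCCCOc3ccc(Cl)cc3)cccc21)c1ccno1` is the next step from compound 3: 1,2-oxazol-5-yl in place of 4-(dimethylamino)phenyl on a carbonyl carbon. Among the compounds with values here, no measured step speaks to this change, and the one step that touches compound 3 is unreadable, so no shift beyond the scatter is expected in this assay. Compound 4 is estimated at 60000 nM, in the range 30000 nM to 150000 nM, most likely reported again as a limit. The expected step that the limit leaves unreadable from compound 3 to compound 4 is thus essentially none.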

Compound 4, half-maximal cytotoxic concentration: 37100 nM
Estimate against measurement, compound 4: 1.6-fold (0.21 log units) above; the range from low to high includes it.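

For the compounds shown here, compound 4 is the first compound here to give a number rather than a limit in this assay, which shows that a change on this carbonyl carbon can bring a compound into the readable range. Placing 1,2-oxazol-5-yl here gives an at least 1.3-fold lower number from compound 3 to compound 4 (0.12 log units; that floor lies within the scatter), and the comparison with phenoxy gives an at least 1.3-fold lower number from compound 2 to compound 4 (0.12 log units; that floor lies within the scatter). Both steps are only floors, so their true sizes remain unknown, and most of the series still sits at the edge of the assay: the limit of > 50000 nM in this assay, at which 3 of the 4 values shown sit.

The compounds shown leave open whether a piperazine or a carboxylic acid on this carbonyl would move the number clearly beyond the scatter. They also leave open whether a longer chain between the shared core and the chlorophenyl ether would change the reading of compound 4.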